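The source may report more compounds than this note shows. Statements on the series, on what has been measured and on what is new or still open speak of the compounds shown alone.

Measured compounds in a functional assay on HT cells (Homo sapiens) for antiproliferative activity, read by fluorescence, with a stated time of 72 h; on this read-out higher numbers stand for weaker inhibition of growth and lower numbers for stronger inhibition of growth:
compound 1 `CC(C)c1n[nH]c2c(NCc3ccc(-c4ccccn4)cc3)nc(SCC(O)CN3CCNCC3)nc12` gives 332 nM
compound 2 `CC(C)c1n[nH]c2c(NCc3ccc(-c4ccccn4)cc3)nc(SCCCN(C)C)nc12` gives 105 nM
compound 3 `CC(C)c1n[nH]c2c(NCc3ccc(-c4ccccn4)cc3)nc(SC3CCCCC3O)nc12` gives 636 nM

Compound 3 stands at the highest number of the three. The nearest step to it is a 1.9-fold higher number from compound 1 to compound 3 (0.28 log units; within the scatter), the widest is a 6.1-fold higher number from compound 2 to compound 3 (0.78 log units; beyond the scatter), and the remaining step among the measured compounds is a 3.2-fold lower number from compound 1 to compound 2 (0.50 log units; beyond the scatter).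

Compound 4 `CC(C)c1n[nH]c2c(NCc3ccc(-c4ccccn4)cc3)nc(SC3CCCCC3N)nc12` is not yet measured. It differs from compound 3 in one place: amino in place of hydroxy on a saturated ring carbon. Going by the values given here, no measured step changes hydroxy to amino directly, so the measured steps bear on it only indirectly. The two compounds that carry a nitrogen-containing group on the sulfur-bound chain, compound 1 with piperazin-1-yl and compound 2 with dimethylamino, give lower numbers than compound 3, the difference being beyond the scatter only for compound 2 a 6.1-fold higher number from compound 2 to compound 3 (0.78 log units; beyond the scatter) and within it for compound 1 a 1.9-fold higher number from compound 1 to compound 3 (0.28 log units; within the scatter). In compound 4 an amino enters on the ring where the hydroxy leaves, a change of a single heavy atom. In this assay a modest move to a lower number is therefore expected, a 2.3-fold lower number from compound 3 to compound 4 (0.36 log units; beyond the scatter), though a result within the scatter of compound 3 would not surprise. For compound 4 the estimate is 280 nM, in the range 110 nM to 700 nM.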

Compound 4, concentration for 50% growth inhibition: 139 nM
Estimate against measurement, compound 4: 2.0-fold (0.30 log units) above; the measured number falls inside the stated range.
By their numbers in this assay, from the lowest: compounds 2 and 4 (each within the scatter of the next); then compounds 1 and 3 (each within the scatter of the next).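

In this assay, going by these compounds alone, this is the first direct reading of amino in place of hydroxy on the saturated ring carbon, and the change of one heavy atom moves the number beyond the scatter (a 4.6-fold lower number from compound 3 to compound 4 (0.66 log units; beyond the scatter)). The 2-aminocyclohexyl group on the sulfur cannot be separated from the open 3-(dimethylamino)propyl chain (a 1.3-fold higher number from compound 2 to compound 4 (0.12 log units; within the scatter)), yet it stands apart from the 2-hydroxy-3-(piperazin-1-yl)propyl chain (a 2.4-fold lower number from compound 1 to compound 4 (0.38 log units; beyond the scatter)), so among these compounds the ring alone does not set the number, as compound 3 and compound 4 both carry it and differ beyond the scatter. Nothing at hand explains why amino and hydroxy differ at this position.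

The compounds shown leave open how a dimethylamino or an aminomethyl group on the same saturated ring carbon would read against amino. They also leave open whether amino in place of hydroxy gives a step of similar size on the open chain of compound 1, where a hydroxy also stands.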